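Returning to a 4-Substituted Pendant Ring on Compound 3

The source may hold more compounds than are shown below. What is called first, only, known or untested is meant among the compounds shown, and "the series" means these compounds.

Compound 3 `COc1ccccc1-c1ccc2ncn(-c3cc(OC)c(OC)c(OC)c3)c2c1` is the weaker of the two compounds that give a number in a functional assay on SGC-7901 cells (Homo sapiens) for antiproliferative activity, read by MTT assay, with a stated time of 72 h; a lower number here means a stronger inhibitor, a higher number a weaker inhibitor; in that assay compound 3 gives 5050 nM. Its nearest relative, compound 1 `COc1cc(-n2cnc3ccc(-c4ccc([N+](=O)[O-])cc4)cc32)cc(OC)c1OC`, gives 79 nM in this assay. The two differ only in the pendant aryl group on the shared core, and a 64-fold higher number from compound 1 to compound 3 (1.81 log units; beyond the scatter). Compound 2 `COc1cc(-c2ccc3ncn(-c4cc(OC)c(OC)c(OC)c4)c3c2)cc(OC)c1OC`, which carries its trimethoxyphenyl group at a different point of the shared core, reaches only a limit of the assay, > 10000 nM, which is a ceiling rather than a measured number (the limit of > 10000 nM in this assay, at which 1 of the 3 values shown sits).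

Compound 4 `COc1cc(-n2cnc3ccc(-c4ccc(F)cc4)cc32)cc(OC)c1OC` is compound 3 with a single change: 4-fluorophenyl in place of 2-methoxyphenyl on an aromatic carbon. Among the compounds with values here, the one measured step that bears on this position is the step from compound 1 to compound 3, and it was large. Compound 4 carries a 4-fluorophenyl where compound 1 carries a 4-nitrophenyl and compound 3 a 2-methoxyphenyl, so the expectation is a step back toward the number of compound 1 rather than no change. Compound 4 is therefore estimated at 350 nM in this assay, with a likely range from 70 nM to 1800 nM. The expected step of a 14-fold lower number from compound 3 to compound 4 (1.16 log units; beyond the scatter) is a clear improvement, though not a full return to the number of compound 1.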

Compound 4, half-maximal inhibitory concentration: 3500 nM
Estimate against measurement, compound 4: 10-fold (1.00 log units) below; the measured number lies above the stated range.
By their numbers in this assay, from the lowest: compound 1; then compounds 4 and 3 (each within the scatter of the next). At a limit, above all of these: compound 2.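

A 4-substituted pendant ring is not enough on its own to recover the number of compound 1: in this assay the change of pendant group gives a 1.4-fold lower number from compound 3 to compound 4 (0.16 log units; within the scatter), so 4-fluorophenyl and 2-methoxyphenyl cannot be told apart at this position of the shared core. The comparison that keeps the substituent at the same place on the pendant ring and exchanges only the group gives a 44-fold higher number from compound 1 to compound 4 (1.65 log units; beyond the scatter), which is nearly as large as the step seen earlier and ties the low number of compound 1 to its 4-nitrophenyl group rather than to the mere presence of a 4-substituent. Nothing measured among these compounds explains why the nitro group stands apart from the fluoro group.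

As far as these compounds go, what remains open is whether the low number belongs to the nitro group alone or would also appear with another group at the same place on the pendant ring, such as a nitrile, a carboxylic acid or an amine. A 4-methoxyphenyl group would also show whether the methoxy group of compound 3 gives a different number when it is moved on the pendant ring.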